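Chloro to Methoxy on a Dimethylpiperazinyl Quinolone Core

The compounds below may be only part of what the source reports. "The series", "measured", "known", "first", "only" and "open" are said of these compounds alone.

The study concerns three measured quinolone-type acids and one that awaits measurement. Compound 1 `CC1(CN)CCN(c2c(F)cc3c(=O)c(C(=O)O)cn(C4CC4)c3c2Cl)C1` is the reference point. In a functional assay on V79 cells (Cricetulus griseus) for cytotoxicity, read by colony formation (a higher number here means a weaker inhibitor, a lower number a stronger inhibitor), compound 1 gives 8 ug/mL. Compound 2 `COc1c(N2CCC(C)(CN)C2)c(F)cc2c(=O)c(C(=O)O)cn(C3CC3)c12` differs from it by methoxy in place of chloro on an aromatic carbon, and in this assay compound 2 gives 38 ug/mL, which is a 4.8-fold higher number from compound 1 to compound 2 (0.68 log units; beyond the scatter). Compound 3 `CC1CN(c2c(F)cc3c(=O)c(C(=O)O)cn(C4CC4)c3c2Cl)CC(C)N1` carries a different amine on the shared core, the difference being (3,5-dimethylpiperazin-1-yl in place of 3-(aminomethyl)-3-methylpyrrolidin-1-yl on an aromatic carbon); in this assay compound 3 gives 140 ug/mL, which is an 18-fold higher number from compound 1 to compound 3 (1.24 log units; beyond the scatter). Compound 3 thus stands with the highest of the three numbers, and both of its steps from the other two lie beyond the scatter.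

Compound 4 `COc1c(N2CC(C)NC(C)C2)c(F)cc2c(=O)c(C(=O)O)cn(C3CC3)c12` differs from compound 3 by methoxy in place of chloro on an aromatic carbon. Among the compounds with values here, this is the same kind of change as the one from compound 1 to compound 2, but the surroundings differ: in compound 1 the exchanged group sits ortho to a 3-(aminomethyl)-3-methylpyrrolidin-1-yl group, whereas in compound 3 it sits ortho to a 3,5-dimethylpiperazin-1-yl group. Within the data shown here, only one example of the change is available, so any carry-over rests on a single step. The step from compound 3 to compound 4 in this assay is expected to be a 3.9-fold higher number from compound 3 to compound 4 (0.59 log units; beyond the scatter), resting on the step seen from compound 1 to compound 2, which was a 4.8-fold higher number from compound 1 to compound 2 (0.68 log units; beyond the scatter). Compound 4 is therefore estimated at 550 ug/mL, with a range from 200 ug/mL to 1500 ug/mL, and the assay might report only a limit rather than a number.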

Compound 4, half-maximal inhibitory concentration: > 500 ug/mL
Compound 4: no number, only a limit (the forecaster's own chance of this, stated with the estimate: 25%); the middle value is on the limit's open side.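

In this assay compound 4 gives only a limit, > 500 ug/mL, and not a number. With 3,5-dimethylpiperazin-1-yl on the shared core, methoxy in place of chloro gives an at least 3.5-fold higher number from compound 3 to compound 4 (0.55 log units; beyond the scatter), so the direction of the change carries over to this second core, although its full size cannot be read and equal size on the two cores is neither shown nor excluded: the same change on two cores in this assay, a 4.8-fold higher number (0.68 log units; beyond the scatter) from compound 1 to compound 2 and an at least 3.5-fold higher number (0.55 log units; beyond the scatter) from compound 3 to compound 4; the limit leaves it open whether they differ The exchange of amine on the methoxy compounds gives an at least 13-fold higher number from compound 2 to compound 4 (1.11 log units; beyond the scatter), which runs in the same direction as the exchange on the chloro compounds, but here too the comparison fixes only the direction and leaves the size unsettled: the same change on two cores in this assay, an 18-fold higher number (1.24 log units; beyond the scatter) from compound 1 to compound 3 and an at least 13-fold higher number (1.11 log units; beyond the scatter) from compound 2 to compound 4; the limit leaves it open whether they differ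

The compounds shown carry only chloro or methoxy at this place and only two amines, so they leave open how a longer chain such as ethoxy would read on either core. Within the data shown here, they also leave open how an unsubstituted piperazin-1-yl group would compare with the 3,5-dimethylpiperazin-1-yl group, and with only two cores in hand, whether the direction of the chloro to methoxy change would hold on a third amine.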